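Adding a Methyl to a Compound Stuck at the Limit

The source may report more compounds than this note shows. Statements on the series, on what has been measured and on what is new or still open speak of the compounds shown alone.

Compound 1 (`CC(=O)N(C)CC#CCn1cncc1C`) gives > 100 mg/kg as a limit
Compound 2 (`CCOC(=O)N(C)CC#CCn1cncc1C`) gives 30 mg/kg as a measured number
Compound 3 (`CN(C)C(=O)N(C)CC#CCn1ccnc1`) gives > 100 mg/kg as a limit

All three compounds were tested in a functional assay on the whole organism for antagonist activity, with Mus musculus as the target (on this read-out lower numbers stand for an effect already at smaller amounts and higher numbers for an effect only at larger amounts of compound), as the read-out. In this assay compound 3 gives > 100 mg/kg and that is a limit. It therefore has no exact place on the scale, and it shares with compound 1 the limit of > 100 mg/kg in this assay, at which 2 of the 3 values shown sit, as its only position.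

Compound 4 (`Cc1cncn1CC#CCN(C)C(=O)N(C)C`) differs from compound 3 by one small change, methyl in place of hydrogen on an aromatic carbon of the ring. Going by the values given here, no measured pair tests this methyl alone. Among the compounds with values here, the one measured step is an at least 3.3-fold lower number from compound 1 to compound 2 (0.52 log units; beyond the scatter) and it changes the group on the carbonyl carbon, not the ring. It bears only indirectly, by showing that the ring methyl can occur in a compound with a measured number, as compound 2 does at 30 mg/kg in this series. Compound 4 keeps the carbonyl group of compound 3, so a modest move to a lower number is expected, with real doubt. The expected size is an at least 1.6-fold lower number from compound 3 to compound 4 (0.22 log units; that floor lies within the scatter) as an estimate only. The estimate for compound 4 is 60 mg/kg with an expected range from 15 mg/kg to 200 mg/kg in this assay as the test.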

Compound 4, dose for half-maximal effect: > 100 mg/kg
Compound 4: no number, only a limit (the forecaster's own chance of this, stated with the estimate: 50%); at least 1.6-fold (0.22 log units) between middle value and limit.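

In this assay compound 4 gives > 100 mg/kg, which is a limit and not a number. The steps from compound 3 and from compound 1 to compound 4 cannot be read, with limits at both ends, so adding the methyl to compound 3 gives no measurable change in either direction. The one readable step is an at least 3.3-fold higher number from compound 2 to compound 4 (0.52 log units; beyond the scatter), for dimethylamino in place of ethoxy on a carbonyl carbon with the ring methyl present on both sides, so the ring methyl alone does not bring a measured number and compound 2 stays the only compound shown with one: the limit of > 100 mg/kg in this assay, at which 3 of the 4 values shown sit.

On these data alone, whether the methyl matters at all stays open, and reading its effect would take a pair with measured numbers at both ends, such as compound 2 set against a partner with hydrogen in place of the ring methyl. Also open, as far as these compounds go, is how a longer chain such as propoxy, or an amine such as pyrrolidine, would behave on the carbonyl carbon in place of ethoxy or dimethylamino.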